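Para substitution on the anilide of the chromone series

The compounds below may be only part of what the source reports. "The series", "measured", "known", "first", "only" and "open" are said of these compounds alone.

Measured compounds in a functional assay (QGY7701 cells, Homo sapiens) for inhibition, read by MTT assay, with a stated time of 48 h; on this read-out higher numbers stand for weaker inhibition and lower numbers for stronger inhibition:
compound 1 `COc1ccc2c(=O)c(/C=C/C(=O)Nc3ccccc3)coc2c1`: 14000 nM
compound 2 `COc1ccc2c(=O)c(/C=C/C(=O)Nc3ccc(F)cc3)coc2c1`: > 100000 nM
compound 3 `COc1ccc2c(=O)c(/C=C/C(=O)NCc3ccc(F)cc3F)coc2c1`: > 100000 nM

Among the measured compounds shown here, compound 1 is the only member with a numerical value. For compound 2 the figure is a limit of this assay, not a number. For compound 3 the figure is likewise a limit. Both limits sit at the limit of > 100000 nM in this assay, at which 2 of the 3 values shown sit.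

The step of an at least 7.1-fold higher number from compound 1 to compound 2 (0.85 log units; beyond the scatter) shows that fluoro in place of hydrogen on an aromatic carbon costs potency. The step of an at least 7.1-fold higher number from compound 1 to compound 3 (0.85 log units; beyond the scatter) shows the same direction for 2,4-difluorobenzyl in place of phenyl on an amide-type nitrogen. The step that the two limits leave unreadable from compound 2 to compound 3 cannot be sized.

Compound 4 `COc1ccc2c(=O)c(/C=C/C(=O)Nc3ccc(C)cc3)coc2c1` carries the change (methyl in place of hydrogen on an aromatic carbon). The step from compound 1 to compound 2 is the closest analogy: a small group entering the anilide ring, and it weakened inhibition. Methyl is a different group from fluoro, so the same loss is not certain, but a step toward weaker inhibition is expected, of at least modest size, with a real chance that only a limit is returned. The expected step is a 2.9-fold higher number from compound 1 to compound 4 (0.46 log units; beyond the scatter). Compound 4 is therefore estimated at 40000 nM, within 10000 nM to 150000 nM.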

Compound 4, half-maximal inhibitory concentration: 39300 nM
Beside the measured number, compound 4's estimate is 1.0-fold (0.01 log units) above it; the measured number falls inside the stated range.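

The position para to a large group on the anilide ring now has a second substituent with a readable result in this assay: methyl in place of hydrogen on an aromatic carbon gives a 2.8-fold higher number from compound 1 to compound 4 (0.45 log units; beyond the scatter), so here the loss of inhibition can be sized rather than ending at a limit. Methyl in place of fluoro at the same place gives an at least 2.5-fold lower number from compound 2 to compound 4 (0.40 log units; beyond the scatter), which separates the two small groups in favour of methyl, though the true size stays open since the figure for compound 2 is a limit. Putting 4-methylphenyl in place of 2,4-difluorobenzyl on an amide-type nitrogen gives an at least 2.5-fold lower number from compound 3 to compound 4 (0.40 log units; beyond the scatter), again a bounded step, while unsubstituted compound 1 keeps the best reading of the series.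

The step from compound 2 to compound 3 cannot be read, and both compounds stand only as limits: the limit of > 100000 nM in this assay, at which 2 of the 4 values shown sit. Whether a methoxy group, a chlorine or an amine at this place would track methyl or fluoro remains open, and so does any reason for the difference between methyl and fluoro.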